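A Fluorophenyl Variant Among Closely Matched Antiproliferative Compounds

The source may hold more compounds than are shown below. What is called first, only, known or untested is meant among the compounds shown, and "the series" means these compounds.

All three compounds built on one shared core have been measured in a functional assay on A-375 cells (Homo sapiens) for antiproliferative activity, read by CCK-8 assay, with a stated time of 72 h, tested at 2 uM; on this read-out higher numbers stand for a stronger effect at the one concentration tested and lower numbers for a weaker effect. Compound 1 `Nc1ccccc1NC(=O)c1ccc(CSC(=S)N2CCN(c3ccc(Cl)cc3)CC2)cc1` gives 32.2%, compound 2 `Nc1ccccc1NC(=O)c1ccc(CSC(=S)N2CCN(Cc3ccncc3)CC2)cc1` gives 33.1%, and compound 3 `Cc1ccc(N2CCN(C(=S)SCc3ccc(C(=O)Nc4ccccc4N)cc3)CC2)cc1` gives 25.8%. Compound 3 holds the lowest of the three numbers, yet its gaps to the others stay within the scatter: a number 6.4 percentage points lower from compound 1 to compound 3 (within the scatter) and a number 7.3 percentage points lower from compound 2 to compound 3 (within the scatter). Compound 4 `Nc1ccccc1NC(=O)c1ccc(CSC(=S)N2CCN(c3ccccc3F)CC2)cc1` differs from compound 3 by 2-fluorophenyl in place of 4-methylphenyl on an amine nitrogen in a ring. All measured steps change the group on that same amine nitrogen in a ring or a substituent on it, and each stayed within the scatter, including a number 0.9 percentage points higher from compound 1 to compound 2 (within the scatter). In this assay the expected step is therefore a number 4.2 percentage points higher from compound 3 to compound 4 (within the scatter), nothing beyond the scatter. Compound 4 is estimated at 30%, between 18% and 42%.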

Compound 4, a percentage reported as inhibition, at one concentration (the size of the read-out at that concentration, not a potency): 18.7%
The estimate for compound 4 lay 11.3 percentage points above the measured number; the range from low to high includes it.
By their numbers in this assay, from the lowest: compounds 4, 3, 1 and 2 (each within the scatter of the next, the first and the last beyond it).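

In this assay, the group on this amine nitrogen in a ring can shift the number beyond the scatter: a number 14.4 percentage points lower from compound 2 to compound 4 (beyond the scatter) and a number 13.5 percentage points lower from compound 1 to compound 4 (beyond the scatter) are both modest steps. Yet a number 7.1 percentage points lower from compound 3 to compound 4 (within the scatter) shows that 2-fluorophenyl and 4-methylphenyl cannot be told apart here, so only part of the series separates.

On these data alone, whether the fluorine or its place on the aromatic ring matters stays open, and an unsubstituted phenyl or a 4-fluorophenyl group on this nitrogen would help separate the two. Nothing shown here offers an explanation for these differences.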